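The source may report more compounds than this note shows. Statements on the series, on what has been measured and on what is new or still open speak of the compounds shown alone.

Measured compounds, cytotoxicity read-out:

Compound 1 `OB1OCc2ccc(-n3cc(Sc4ccc(F)cc4)c4ccccc43)cc21`: in an ADME assay on L929 cells (Mus musculus) for cytotoxicity, read by resazurin assay, with a stated time of 72 h (on this read-out lower numbers stand for stronger inhibition and higher numbers for weaker inhibition), compound 1 gives > 10 ug/mL, which is a limit of the assay and not a number.
Compound 2 `CCCNC(=O)c1cccn1-c1ccc2c(c1)B(O)OC2`: in this assay compound 2 gives > 10 ug/mL, again a limit.
Compound 3 `O=C(NCc1ccccc1)c1cccn1-c1ccc2c(c1)B(O)OC2`: in this assay compound 3 gives > 10 ug/mL, also a limit.

Compound 3 therefore stands at the same limit as the two other measured compounds, and nothing separates it from them on the numbers shown (the limit of > 10 ug/mL in this assay, at which 3 of the 3 values shown sit). Among the compounds with values here, the only single-point step with numbers, a step that the two limits leave unreadable from compound 2 to compound 3, is unreadable, since both ends are limits.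

Compound 4 `CCNC(=O)c1cccn1-c1ccc2c(c1)B(O)OC2` is not yet measured. It differs from compound 3 in one place: methyl in place of phenyl on a saturated chain carbon bound to an amide-type nitrogen. Within the data shown here, the step from compound 2 to compound 3 is the only measured step that touches this place, and it gives no readable size. On that basis the step is expected to stay unreadable, an expected change of a step that the limit leaves unreadable from compound 3 to compound 4 in this assay. Compound 4 is estimated at 30 ug/mL, within the range 10 ug/mL to 100 ug/mL, most likely again reported as a limit.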

Compound 4, half-maximal inhibitory concentration: > 10 ug/mL
Compound 4: a limit, no number; the forecaster's own chance of this, stated with the estimate: 85%; the middle value is on the limit's open side.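

No new step can be read among compound 2, compound 3 and compound 4, since each end of every step is a limit and not a number: the limit of > 10 ug/mL in this assay, at which 4 of the 4 values shown sit.

The compounds shown leave open how far any of them lies beyond that limit, and whether changing the amide chain alters cytotoxicity at all.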